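From pyrrolidin-2-yl to 4-hydroxyphenyl on compound 2

The source may hold more compounds than are shown below. What is called first, only, known or untested is meant among the compounds shown, and "the series" means these compounds.

In a functional assay on MIA PaCa-2 cells (Homo sapiens) for antiproliferative activity, read by MTT assay, with a stated time of 24 h (a lower number here means a stronger inhibitor, a higher number a weaker inhibitor), compound 1 (`c1ccc(-c2noc(-c3ccncc3)n2)cc1`) gives 497000 nM and compound 2 (`COc1ccc(-c2noc(C3CCCN3)n2)cc1OC1CCCC1`) gives 19500 nM as the lower of the two numbers, making it the stronger inhibitor of this pair. Compound 3 (`COc1ccc(-c2noc(-c3ccc(O)cc3)n2)cc1OC1CCCC1`) carries 4-hydroxyphenyl in place of pyrrolidin-2-yl on an aromatic carbon. Among the compounds with values here, no measured pair of compounds isolates this swap, so the guidance is thin. In this assay the expected result is a 1.2-fold lower number from compound 2 to compound 3 (0.09 log units; within the scatter) as a step no larger than the usual scatter, with no firm direction. Compound 3 is estimated at 16000 nM (range 4500 nM to 60000 nM).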

Compound 3, half-maximal inhibitory concentration: 480 nM
Estimate against measurement, compound 3: 33-fold (1.52 log units) above; measured number outside the range, below it.
By their numbers in this assay, from the lowest: compound 3; then compound 2; then compound 1.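

In this assay the swap of pyrrolidin-2-yl for 4-hydroxyphenyl gives a 41-fold lower number from compound 2 to compound 3 (1.61 log units; beyond the scatter) and so shows that the group on this aromatic carbon strongly affects the result. Compounds 1 and 2 differ in more than one place, so they could not show this for the position alone. Nothing available accounts for the size of this step. The compounds shown leave open whether the gain rests on the hydroxy group or on the aromatic ring that carries it; a plain phenyl, 4-methoxyphenyl or 4-aminophenyl at this position would help separate the two.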